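The compounds below may be only part of what the source reports. "The series", "measured", "known", "first", "only" and "open" are said of these compounds alone.

Compound 3 `Fc1cnc(N2CCN(CCCCC3CCCCC3)CC2)nc1` is the reference point for this step, yet it carries no single number: in an assay (Cavia porcellus) for displacement of a labelled ligand from Sigma non-opioid intracellular receptor 1 (Homo sapiens) (on this read-out higher numbers stand for weaker inhibition and lower numbers for stronger inhibition), compound 3 shows no result reported, so where it stands can only be inferred from its neighbours. The nearest measured neighbour is compound 1 `OC(CCCN1CCN(c2ncc(F)cn2)CC1)C1CCCCC1`, which bears a cyclohexyl(hydroxy)methyl group three bonds along the chain from the ring amine nitrogen and in this assay gives 12 nM. Going by the values given here, compound 2 `Fc1ccc(SCCCN2CCN(c3ncc(F)cn3)CC2)cc1`, with (4-fluorophenyl)sulfanyl at that position, gives 51 nM in this assay; the one step recorded between measured compounds is a 4.3-fold higher number from compound 1 to compound 2 (0.63 log units; beyond the scatter), a change in a different part of the molecule from the one considered here.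

Compound 4 `NC(CCCN1CCN(c2ncc(F)cn2)CC1)C1CCCCC1` differs from compound 3 by amino in place of hydrogen on a saturated chain carbon bound to a saturated chain carbon and a saturated ring carbon. Among the compounds with values here, no measured step swaps hydrogen for amino, so nothing recorded bears directly on this change, and the measured step gives no direction for it. What the data offer is the hydroxy-bearing compound 1, which reaches 12 nM; an amino group at that carbon is expected to land in the same region. Compound 4 is therefore estimated at 15 nM in this assay, within a range of 4 nM to 60 nM.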

Compound 4, half-maximal inhibitory concentration: 52 nM
Compound 4: the middle estimate sits 3.5-fold (0.54 log units) below what was measured, within the range that was stated.
By their numbers in this assay, from the lowest: compound 1; then compounds 2 and 4 (each within the scatter of the next).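

In this assay the new result shows that this carbon does not treat its two heteroatom groups alike: amino in place of hydroxy brings a 4.3-fold higher number from compound 1 to compound 4 (0.64 log units; beyond the scatter) and so gives up the lower number held by compound 1. At the chain position, amino(cyclohexyl)methyl in place of (4-fluorophenyl)sulfanyl brings a 1.0-fold higher number from compound 2 to compound 4 (0.01 log units; within the scatter) and so leaves no readable difference between these two quite different groups, while the hydroxy-bearing compound 1 stays apart from both. The step from compound 3 cannot be read, as compound 3 carries no number, so what amino adds over hydrogen remains unknown, and nothing measured here accounts for the gap between amino and hydroxy.

The compounds shown leave open how a methoxy group, an N-methylamino group or a dimethylamino group would read at this carbon, and so whether the result for compound 4 holds for amines more widely. They also leave open whether a longer chain between this carbon and the ring amine nitrogen would keep the standing of compound 1 over compound 4.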